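Sulfonylurea series: varying the amine on the sulfonyl sulfur

The source may hold more compounds than are shown below. What is called first, only, known or untested is meant among the compounds shown, and "the series" means these compounds.

Measured so far:
compound 1 `CC(C)NS(=O)(=O)NC(=O)Nc1c(C(C)C)cccc1C(C)C` — in an assay on liver for inhibition of sterol O-acyltransferase 1 (Rattus norvegicus), using microsomes (on this read-out lower numbers stand for stronger inhibition and higher numbers for weaker inhibition), compound 1 gives 18000 nM
compound 2 `CC(C)c1cccc(C(C)C)c1NC(=O)NS(=O)(=O)N1CCCC1` — in this assay compound 2 gives 15000 nM

Compound 2 holds the lowest of the two numbers, but the step of a 1.2-fold lower number from compound 1 to compound 2 (0.08 log units; within the scatter) lies within the scatter, so no order between the two is claimed. Compound 3 `CCCCN(C)S(=O)(=O)NC(=O)Nc1c(C(C)C)cccc1C(C)C` carries butyl(methyl)amino in place of pyrrolidin-1-yl on a sulfonyl sulfur. Among the measured compounds shown here, the only measured step, a 1.2-fold lower number from compound 1 to compound 2 (0.08 log units; within the scatter), also exchanged the amine on the sulfonyl sulfur and moved little, so for compound 3 the expected step in this assay is none beyond the scatter, no change at the digits printed from compound 2 to compound 3 (within the scatter). Compound 3 is therefore estimated at 15000 nM, within 6000 nM to 40000 nM.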

Compound 3, half-maximal inhibitory concentration: 2300 nM
Compound 3: the middle estimate sits 6.5-fold (0.81 log units) above what was measured, outside the stated range (below it).
By their numbers in this assay, from the lowest: compound 3; then compounds 2 and 1 (each within the scatter of the next).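

The amine on the sulfonyl sulfur is not a silent position in this assay: butyl(methyl)amino in place of pyrrolidin-1-yl gives a 6.5-fold lower number from compound 2 to compound 3 (0.81 log units; beyond the scatter), and butyl(methyl)amino in place of isopropylamino gives a 7.8-fold lower number from compound 1 to compound 3 (0.89 log units; beyond the scatter). Exchange at this place can therefore move the number beyond the scatter, which the step between the first two amines did not show. Nothing available here accounts for this difference.

As far as these compounds go, whether the butyl chain or the methyl on the nitrogen carries the step stays open; butylamino would help separate the two. From the compounds shown here alone, how a longer chain, as in hexyl(methyl)amino, would read also remains open.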